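Cytotoxicity Outlook for a Third Analogue

The compounds below may be only part of what the source reports. "The series", "measured", "known", "first", "only" and "open" are said of these compounds alone.

Compound 1, `CCOC(=O)c1cnc(N2CCN(Cc3ccccc3C(F)(F)F)CC2)nc1Oc1c(C)cc(-c2ccc(C#N)cc2)cc1C`: > 125000 nM
Compound 2, `CCOC(=O)c1cnc(N2CCN(Cc3ccc(Br)cc3)CC2)nc1Oc1c(C)cc(-c2ccc(C#N)cc2)cc1C`: > 125000 nM

In an ADME assay on MT4 cells (Homo sapiens) for cytotoxicity, read by MTT assay, with a stated time of 4 days (on this read-out lower numbers stand for higher toxicity in this test and higher numbers for lower toxicity in this test), compound 1 reaches only the limit of the assay, > 125000 nM. In this assay compound 2 likewise stops at the limit, > 125000 nM. The step that the two limits leave unreadable from compound 1 to compound 2 therefore cannot be read. Compound 3, `CCOC(=O)c1cnc(N2CCN(Cc3cc(C)cc(C)c3)CC2)nc1Oc1c(C)cc(-c2ccc(C#N)cc2)cc1C`, carries the change (3,5-dimethylphenyl in place of 4-bromophenyl on a saturated chain carbon bound to an amine nitrogen in a ring). For the measured compounds named here, the single known step gives no guidance on its size, because both measured values sit at the limit of > 125000 nM in this assay, at which 2 of the 2 values shown sit. No shift beyond the scatter is expected. Compound 3 is expected to give 125000 nM, between 50000 nM and 300000 nM, an expected step of a number no higher from compound 2 to compound 3 (the limit leaves the size open).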

Compound 3, half-maximal cytotoxic concentration: > 125000 nM
Compound 3: only a limit was reported; the forecaster's own chance of this, stated with the estimate: 80%; the middle value lies on the limit itself.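

Compound 3 also stops at a limit of the assay in this assay, so its steps from compound 1 and compound 2 cannot be read: the limit of > 125000 nM in this assay, at which 3 of the 3 values shown sit.

The compounds shown leave open whether these three compounds differ in cytotoxicity at all.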